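Halogen swap on the chalcone aryl ring

The source may hold more compounds than are shown below. What is called first, only, known or untested is meant among the compounds shown, and "the series" means these compounds.

Compounds measured so far:
compound 1 `COc1ccc(-c2cc(/C=C/C(=O)c3ccc(N)cc3)[nH]n2)cc1` with -61%
compound 2 `COc1cc(-c2cc(/C=C/C(=O)c3ccc(Cl)c(Cl)c3)[nH]n2)cc(OC)c1OC` with -51%
compound 3 `COc1ccc(C(=O)/C=C/c2cc(-c3cc(OC)c(OC)c(OC)c3)n[nH]2)cc1OC` with 3%

These three compounds share a core and differ in the ring attached to the carbonyl carbon. In a functional assay on SR cells (Homo sapiens) for cytotoxicity, read by sulforhodamine B assay, with a stated time of 48 h, tested at 100 uM (a higher number here means a weaker effect of the compound at the concentration tested, a lower number a stronger effect), compound 2 gives -51%, the second highest of the three numbers. Compound 1 sits nearest, with a number lower but within the scatter, so the two cannot be ordered. Compound 3 sits furthest away, and the step of a number 54 percentage points higher from compound 2 to compound 3 (beyond the scatter) is large and beyond the scatter.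

Compound 4 `COc1cc(-c2cc(/C=C/C(=O)c3ccc(F)c(F)c3)[nH]n2)cc(OC)c1OC` is not yet measured. It differs from compound 2 in one place: 3,4-difluorophenyl in place of 3,4-dichlorophenyl on a carbonyl carbon

Among the compounds with values here, the only measured step that bears on this change is the one from compound 2 to compound 3, where a 3,4-dimethoxyphenyl replaced the 3,4-dichlorophenyl and the number rose sharply. Here the replacement keeps a halogen pair on the same ring, which is a closer relative of the departing group than the dimethoxyphenyl was. A move in the same upward direction is therefore plausible, but a smaller one is expected, and a change within the scatter cannot be excluded. Compound 4 is expected to give -35%, with a range from -70% to 10%. The expected step is a number 16 percentage points higher from compound 2 to compound 4 (beyond the scatter).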

Compound 4, a percentage reported as activity, at one concentration (the size of the read-out at that concentration, not a potency): 8%
For compound 4 the middle estimate is 43 percentage points below the measured one; the measured number falls inside the stated range.
By their numbers in this assay, from the lowest: compounds 1 and 2 (each within the scatter of the next); then compounds 3 and 4 (each within the scatter of the next).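

Swapping the 3,4-dichlorophenyl on the carbonyl carbon for 3,4-difluorophenyl gives, in this assay, a number 59 percentage points higher from compound 2 to compound 4 (beyond the scatter) even though both groups have the same ring and the same count of heavy atoms, so keeping a halogen pair at this position does not keep the read-out. The new compound also reads much like the one with the 3,4-dimethoxyphenyl group, with a number 5 percentage points higher from compound 3 to compound 4 (within the scatter) and, among these three compounds, only the 3,4-dichlorophenyl group of compound 2 stands apart from the other two. Nothing measured here explains why two halogen pairs on the same ring should differ so strongly.

The compounds shown leave open where along the halogens the read-out shifts, since a 3,4-dibromophenyl group, a single chlorine or a single fluorine on the ring would each test whether the effect belongs to the chlorine pair alone. They also leave open whether the same swap behaves alike on the core of compound 1, whose other ring carries one methoxy group rather than three, or with an amine or a trifluoromethyl group at this place.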